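The compounds below may be only part of what the source reports. "The series", "measured", "known", "first", "only" and "open" are said of these compounds alone.

Compound 1 `CC(C)(C)[Si](C)(C)O[C@@H]1CCCO[C@@H]1CO` reads > 100000 nM in a functional assay on A2780 cells (Homo sapiens) for antiproliferative activity, read by sulforhodamine B assay, with a stated time of 48 h (a lower number here means a stronger inhibitor of growth, a higher number a weaker inhibitor of growth), as a limit of the assay, not a number. Going by the values given here, compound 2 `CC(C)(C)[Si](C)(C)O[C@@H]1CCCO[C@@H]1CO/C=C/C(=O)OCc1ccccc1` gives 26000 nM in this assay and holds the only actual number so far. Compound 3 `COC(=O)/C=C/OC[C@H]1OCCC[C@H]1O[Si](C)(C)C(C)(C)C` differs from compound 2 by hydrogen in place of phenyl on a saturated chain carbon bound to an oxygen next to a carbonyl group as hydrogen in place of phenyl on a saturated chain carbon bound to an oxygen next to a carbonyl group, benzyl to methyl. No measured step sizes this change, so only a small loss of growth inhibition is expected, perhaps none beyond the scatter. The expected move is a 1.5-fold higher number from compound 2 to compound 3 (0.19 log units; within the scatter) in this assay as a working figure. For compound 3 the estimate is 40000 nM with an expected range of 15000 nM to 100000 nM pending measurement.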

Compound 3, concentration for 50% growth inhibition: 30000 nM
Compound 3: the middle estimate sits 1.3-fold (0.12 log units) above what was measured; the measured number falls inside the stated range.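

In this assay, the change of benzyl to methyl gives a 1.2-fold higher number from compound 2 to compound 3 (0.06 log units; within the scatter), so at this ester position the phenyl can be lost with no change beyond the scatter. Placing 2-(methoxycarbonyl)ethenyl in place of hydrogen on an oxygen on a saturated carbon gives an at least 3.3-fold lower number from compound 1 to compound 3 (0.52 log units; beyond the scatter), the first step in the series beyond the scatter. That step is a bound and not a size, since compound 1 reads a limit of the assay: the limit of > 100000 nM in this assay, at which 1 of the 3 values shown sits.

As far as these compounds go, whether a carboxylic acid or an amide in place of the methyl ester holds this level remains open. So does the effect of a longer chain than methyl.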